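The compounds below may be only part of what the source reports. "The series", "measured", "known", "first", "only" and "open" are said of these compounds alone.

In an ADME assay on MT4 cells (Homo sapiens) for cytotoxicity, read by MTT assay (on this read-out higher numbers stand for lower toxicity in this test and lower numbers for higher toxicity in this test), so far:
- compound 1 `O=C(CSc1nnnn1-c1cccc2ccccc12)N/N=C/c1ccc([N+](=O)[O-])cc1` gives >= 260000 nM, a limit of the assay and not a number
- compound 2 `O=C(CSc1nnnn1-c1cccc2ccccc12)N/N=C/c1ccccc1O` gives 4850 nM, a number

Within the data shown here, compound 2 holds the only true number, so it can be placed against nothing but a limit. The next compound is compound 3 `CN(C)c1ccc(/C=N/NC(=O)CSc2nnnn2-c2cccc3ccccc23)cc1`, with 4-(dimethylamino)phenyl in place of 2-hydroxyphenyl on a carbon with a double bond to nitrogen.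

Among the measured compounds shown here, one measured step bears on this place. The change an at least 53-fold lower number from compound 1 to compound 2 (1.72 log units; beyond the scatter) is large and beyond the scatter, with 2-hydroxyphenyl in place of 4-nitrophenyl. Exchange at this place can therefore move the number strongly in this assay, and compound 3 also gives up the 2-hydroxyphenyl that goes with the lower number of the pair. On this single step, a rise to a higher number, meaning lower toxicity in this test, is expected, though smaller than the measured step. The expected change is a 4.1-fold higher number from compound 2 to compound 3 (0.62 log units; beyond the scatter), and it rests on little evidence. Compound 3 is estimated at 20000 nM, with an expected range of 5000 nM to 120000 nM as the outer ends.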

Compound 3, half-maximal cytotoxic concentration: > 289000 nM
Compound 3: only a limit was reported; the forecaster's own chance of this, stated with the estimate: 25%; middle value at least 14-fold (1.15 log units) away from the limit.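

In this assay, 4-(dimethylamino)phenyl in place of 2-hydroxyphenyl on a carbon with a double bond to nitrogen gives an at least 59-fold higher number from compound 2 to compound 3 (1.77 log units; beyond the scatter), so a second exchange at this place also moves the number strongly, and the large size of the first step was not unique to 4-nitrophenyl. Compound 3 gives > 289000 nM, which is a limit of the assay and not a number. Among these compounds, the only true number, and with it the higher toxicity in this assay, goes with 2-hydroxyphenyl, while 4-nitrophenyl and 4-(dimethylamino)phenyl both end at limits, with no compound here going against this.

From the compounds shown here alone, the step from compound 1 to compound 3 cannot be read, so 4-nitrophenyl and 4-(dimethylamino)phenyl cannot be ordered in this test, and how far either lies from compound 2 remains unknown. Also open, going by these compounds, is whether the low number depends on the hydroxy group itself or on the whole 2-hydroxyphenyl group, a question that unsubstituted phenyl, 4-hydroxyphenyl and 2-methoxyphenyl at this place could help to separate.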